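The compounds below may be only part of what the source reports. "The series", "measured", "known", "first", "only" and "open" are said of these compounds alone.

Compound 1 `CC(C)(C)c1ccc(CCC(=S)NCc2ccc(NS(C)(=O)=O)c(F)c2)cc1` is the starting point of the comparison. In a functional assay for antagonist activity at transient receptor potential cation channel subfamily V member 1 (Rattus norvegicus) (a higher number here means a weaker inhibitor, a lower number a stronger inhibitor), compound 1 gives 40 nM, the lowest of the two numbers in hand. Among the compounds with values here, its only measured neighbour is compound 2 `CC(C)(C)c1ccc(CCC(=S)NCc2ccc(NS(C)(=O)=O)c(C(F)(F)F)c2)cc1`, which in this assay gives 940 nM; the step of a 24-fold higher number from compound 1 to compound 2 (1.37 log units; beyond the scatter), trifluoromethyl in place of fluoro on an aromatic carbon, is the single measured step available, and it lies well beyond the scatter.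

Compound 3 `CC(C)(C)c1ccc(CCC(=S)NCc2cc(F)c(NS(C)(=O)=O)c(C#N)c2)cc1` has not yet been measured in this assay. It differs from compound 1 by cyano in place of hydrogen on an aromatic carbon. The step from compound 1 to compound 2 is the only one that bears on this change, and it shows that a substitution on the same ring of the shared core can cost a great deal. A cyano entering in place of hydrogen is a different and smaller substitution than trifluoromethyl for fluoro, so compound 3 is expected to lose some potency but less than compound 2 did, with an expected step of a 2.8-fold higher number from compound 1 to compound 3 (0.44 log units; beyond the scatter). Compound 3 is therefore estimated at 110 nM in this assay, in a range from 30 nM to 450 nM.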

Compound 3, half-maximal inhibitory concentration: 28 nM
Estimate against measurement, compound 3: 3.9-fold (0.59 log units) above; the whole stated range lies above it.
By their numbers in this assay, from the lowest: compounds 3 and 1 (each within the scatter of the next); then compound 2.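

In this assay, placing cyano on the aromatic carbon ortho to a methanesulfonamido group and meta to a fluoro group gives a 1.4-fold lower number from compound 1 to compound 3 (0.15 log units; within the scatter) and so leaves the number indistinguishable from that of the parent. The only earlier step, a 24-fold higher number from compound 1 to compound 2 (1.37 log units; beyond the scatter), had shown a heavy cost for trifluoromethyl in place of fluoro, whereas this result shows that not every substitution on this ring of the shared core carries such a cost, and that this position accepts cyano while the fluoro group of compound 1 stays in place. Nothing in hand explains why the cyano group is accepted here.

From the compounds shown here alone, it remains open whether this position would accept groups other than cyano, such as an amine, a carboxylic acid, a methoxy group or a chlorine atom, since a single substituent cannot show how far the tolerance extends. Going by these compounds, it is also open whether cyano would give the same result with hydrogen or trifluoromethyl in place of the fluoro group.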